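The source may report more compounds than this note shows. Statements on the series, on what has been measured and on what is new or still open speak of the compounds shown alone.

Compounds 1, 2 and 3 share one core and differ only in the group on a carbonyl carbon. In a functional assay on cells (Lymphocyte) (a higher number here means a weaker inhibitor, a lower number a stronger inhibitor), compound 1 `Nc1nc(N2CCN(C(=O)CCc3ccccc3)CC2)c2cc(F)sc2n1` gives 6990 nM. Compound 2 `Nc1nc(N2CCN(C(=O)c3cccnc3)CC2)c2cc(F)sc2n1` reaches only the limit of > 10000 nM in this assay. Compound 3 `Cc1cccc(NC(=O)N2CCN(c3nc(N)nc4sc(F)cc34)CC2)c1` gives 2800 nM, the lowest of the two numbers; it is set apart by a 2.5-fold lower number from compound 1 to compound 3 (0.40 log units; beyond the scatter) and an at least 3.5-fold lower number from compound 2 to compound 3 (0.55 log units; beyond the scatter), whereas an at least 1.4-fold higher number from compound 1 to compound 2 (0.15 log units; that floor lies within the scatter). Compound 4 `CC(C)N(C(=O)N1CCN(c2nc(N)nc3sc(F)cc23)CC1)C(C)C` carries diisopropylamino in place of (3-methylphenyl)amino on a carbonyl carbon. Among the compounds with values here, no measured step removes the aromatic ring outright; the nearest comparison, a 2.5-fold lower number from compound 1 to compound 3 (0.40 log units; beyond the scatter), exchanged one ring-bearing group for another. The change expected here is therefore a modest rise in the number, a 2.1-fold higher number from compound 3 to compound 4 (0.33 log units; beyond the scatter), and compound 4 is estimated at 6000 nM, within a range from 2000 nM to 15000 nM.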

Compound 4, half-maximal inhibitory concentration: 8200 nM
For compound 4 the middle estimate is 1.4-fold (0.14 log units) below the measured one; the measured number falls inside the stated range.
By their numbers in this assay, from the lowest: compound 3; then compounds 1 and 4 (each within the scatter of the next). At a limit, above all of these: compound 2.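

Within the data shown here, the step of a 2.9-fold higher number from compound 3 to compound 4 (0.47 log units; beyond the scatter) is the first in this assay in which the group on the carbonyl carbon loses both its aromatic ring and its hydrogen-bond donor. Diisopropylamino in place of phenethyl gives a 1.2-fold higher number from compound 1 to compound 4 (0.07 log units; within the scatter), so a group with no ring and a ring-bearing one cannot be told apart here. Compound 2 stands at a limit: the limit of > 10000 nM in this assay, at which 1 of the 4 values shown sits. Against that limit, the step reads only as a floor: an at least 1.2-fold lower number from compound 2 to compound 4 (0.08 log units; that floor lies within the scatter).

Ring and donor leave together, so the compounds shown do not tell which of the two goes with the step. Isopropylamino, which keeps the amide hydrogen without a ring, and methyl(phenyl)amino, which keeps the ring without that hydrogen, would separate them.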